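Swapping 2,5-dimethoxyphenyl for anilino on the shared core

The source may report more compounds than this note shows. Statements on the series, on what has been measured and on what is new or still open speak of the compounds shown alone.

In a functional assay on Jurkat cells (Homo sapiens) for antiproliferative activity, read by MTT assay, with a stated time of 72 h (on this read-out higher numbers stand for weaker inhibition and lower numbers for stronger inhibition), compound 1 `COc1cc(C(=O)c2sc3ccccc3c2-c2ccc(C)cc2)cc(OC)c1OC` gives 3300 nM. Compound 2 `COc1cc(C(=O)c2sc3ccccc3c2-c2ccc(SC)cc2)cc(OC)c1OC` gives 1900 nM, with a 1.7-fold lower number from compound 1 to compound 2 (0.24 log units; within the scatter).

Compound 3 `COc1ccc(OC)c(-c2c(C(=O)c3cc(OC)c(OC)c(OC)c3)sc3ccccc23)c1` gives > 10000 nM, which is a limit of the assay and not a number.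

Compound 4 `COc1cc(C(=O)c2sc3ccccc3c2Nc2ccccc2)cc(OC)c1OC` carries anilino in place of 2,5-dimethoxyphenyl on an aromatic carbon of the five-membered ring: anilino in place of 2,5-dimethoxyphenyl on an aromatic carbon. For the measured compounds named here, no measured step involves anilino. The nearest guides are the two steps that change the group at this same carbon, an at least 3.0-fold higher number from compound 1 to compound 3 (0.48 log units; beyond the scatter) and an at least 5.2-fold higher number from compound 2 to compound 3 (0.72 log units; beyond the scatter). Read in reverse, they suggest that leaving 2,5-dimethoxyphenyl could bring a modestly lower number, into the range of compound 1 at 3300 nM. The expected change in this assay is an at least 2.5-fold lower number from compound 3 to compound 4 (0.39 log units; beyond the scatter), which remains uncertain since compound 3 offers only a limit as its starting point. For compound 4, the estimated value is 4000 nM, with an expected range from 1000 nM to 10000 nM.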

Compound 4, half-maximal inhibitory concentration: 1600 nM
Estimate against measurement, compound 4: 2.5-fold (0.40 log units) above, and the stated range covers the measured number.
By their numbers in this assay, from the lowest: compounds 4, 2 and 1 (each within the scatter of the next, the first and the last beyond it). At a limit, above all of these: compound 3.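

In this assay, anilino at this carbon of the five-membered ring gives an at least 6.2-fold lower number from compound 3 to compound 4 (0.79 log units; beyond the scatter), and this step can only be read as a minimum, as it starts from a limit of the assay: the limit of > 10000 nM in this assay, at which 1 of the 4 values shown sits. Anilino in place of 4-(methylsulfanyl)phenyl gives a 1.2-fold lower number from compound 2 to compound 4 (0.07 log units; within the scatter), so these two groups cannot be told apart here, whereas anilino in place of 4-methylphenyl gives a 2.1-fold lower number from compound 1 to compound 4 (0.31 log units; beyond the scatter), a modest gain. Among the compounds shown, then, a ring joined directly to this carbon is not needed for activity, and anilino, with its hydrogen-bond donor, is tolerated.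

The compounds shown leave open whether the linking nitrogen and its hydrogen matter, or only the ring that nitrogen carries. A phenoxy or a benzylamino group at this carbon would help separate these possibilities.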